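Fluorinated Carbocycle Replaces Oxetanyl Carbamate on the Piperidine Amide

The source may report more compounds than this note shows. Statements on the series, on what has been measured and on what is new or still open speak of the compounds shown alone.

Measured compounds:
compound 1 `Cc1nc(S(C)(=O)=O)ccc1Oc1ncnc(OC2CCN(C(=O)OC(C)F)CC2)c1F` 315 nM
compound 2 `Cc1nc(S(C)(=O)=O)ccc1Oc1ncnc(OC2CCN(C(=O)OC3COC3)CC2)c1F` 2500 nM

Of the two numbers seen in a functional assay on isolated protein for inhibition of Glucose-dependent insulinotropic receptor (Rattus norvegicus), read by HTRF and cAMP accumulation (a lower number here means that less compound is needed, a higher number that more compound is needed for the effect), compound 2 has the highest, and its nearest neighbour is compound 1, which lies a 7.9-fold higher number from compound 1 to compound 2 (0.90 log units; beyond the scatter) in the other direction. Compound 3 `Cc1nc(S(C)(=O)=O)ccc1Oc1ncnc(OC2CCN(C(=O)C3(F)CCC3)CC2)c1F` differs from compound 2 by a group of 5 heavy atoms (4 carbon, 1 fluorine; one four-membered non-aromatic ring of carbon only) in place of a group of 5 heavy atoms (3 carbon, 2 oxygen; one four-membered non-aromatic ring with 1 hetero atom), on a carbonyl carbon. Going by the values given here, the only measured step that bears on this is a 7.9-fold higher number from compound 1 to compound 2 (0.90 log units; beyond the scatter), where a 1-fluoroethyl group on the oxygen gave way to oxetan-3-yl; compound 3 now removes that oxetan-3-yl group and its oxygen altogether and brings a fluorine-bearing carbon ring directly onto the carbonyl carbon. Since compound 2 sits at the high end because of a 7.9-fold higher number from compound 1 to compound 2 (0.90 log units; beyond the scatter), compound 3 is expected to move back toward compound 1, with a 4.2-fold lower number from compound 2 to compound 3 (0.62 log units; beyond the scatter) as a modest step. Compound 3 is therefore estimated at 600 nM, within 150 nM to 2400 nM.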

Compound 3, half-maximal effective concentration: 123 nM
Compound 3: middle estimate off by 4.9-fold (0.69 log units), on the high side; the measured number lies below the stated range.
By their numbers in this assay, from the lowest: compound 3; then compound 1; then compound 2.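

In this assay, the change on the carbonyl carbon gave a 20-fold lower number from compound 2 to compound 3 (1.31 log units; beyond the scatter), a large step that shows this position can respond strongly to the group placed there. The new group did more than recover the loss seen with the oxetan-3-yl group, as it also gave a 2.6-fold lower number from compound 1 to compound 3 (0.41 log units; beyond the scatter), so both steps place the fluorinated four-membered carbon ring lowest of the three groups, beyond the scatter. Nothing available explains why the number falls with this group.

As far as these compounds go, what a plain cyclobutyl group without the fluorine would give on this carbonyl carbon remains open, so the part played by the fluorine in these steps cannot be separated from that of the ring. A cyclopentyl ring in the same place also remains an open question, leaving it unknown whether the four-membered ring size matters.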